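Fluoro on the pendant phenyl: expected microsomal stability

A few compounds are considered here, and "the series" means these few. Any claim that something is new, unique, unknown or untested is made for them only; others in the source may bear on it.

Measured compounds:
compound 1 `C[C@H](Nc1ncnc2[nH]cnc12)c1cc2ccc(F)cn2c(=O)c1-c1ccccc1` — 95%
compound 2 `C[C@H](Nc1nc(N)nc(N)c1C#N)c1cc2ccc(F)cn2c(=O)c1-c1ccccc1` — 88%

In an ADME assay on microsomes from liver (Rattus norvegicus), read by LC-MS, using NADPH, with a stated time of 30 min, tested at 1 uM (on this read-out lower numbers stand for a less stable compound and higher numbers for a more stable compound), compound 1 gives 95%, and compound 2 gives 88%. Going by the values given here, the only measured step, a number 7 percentage points lower from compound 1 to compound 2 (within the scatter), swaps the group on the amine nitrogen and leaves both numbers high. Compound 2 stands lowest of the two numbers, but its gap to compound 1 is within the scatter, so no order between them can be read.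

Compound 3 `C[C@H](Nc1nc(N)nc(N)c1C#N)c1cc2ccc(F)cn2c(=O)c1-c1ccc(F)cc1` differs from compound 2 by fluoro in place of hydrogen on an aromatic carbon. Among the compounds with values here, no measured step touches this part of the molecule: the one step on record concerns the amine substituent, not the phenyl ring, so nothing in the data points to a change beyond the scatter. Both measured compounds sit near the top of the read-out, which leaves little room upward.

Compound 3 is therefore expected to give 88% in this assay, with a range of 72% to 97%. The expected step of no change at the digits printed from compound 2 to compound 3 (within the scatter) is estimated to lie within the scatter.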

Compound 3, percent of the compound remaining: 87%
Estimate against measurement, compound 3: 1 percentage points above, and the stated range covers the measured number.
By their numbers in this assay, from the lowest: compounds 3, 2 and 1 (each within the scatter of the next).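

In this assay, fluoro in place of hydrogen on an aromatic carbon, para to a large group on the six-membered aromatic ring of carbon only, gives a number 1 percentage points lower from compound 2 to compound 3 (within the scatter), so the two compounds cannot be told apart on this read-out. Going by these compounds alone, the earlier step concerned only the group on the amine nitrogen, so this is the first reading from the phenyl ring itself: with that group held constant, phenyl and 4-fluorophenyl give numbers that lie within the scatter of each other, and this position accepts a fluoro without a separation from compound 2 in this assay. No measurement at hand offers an explanation for this result.

A single fluorine is a small replacement at one place on the ring, so the compounds shown leave open whether a larger group at the same carbon, such as methoxy, trifluoromethyl or an amine, would also stay within the scatter of compound 2. They also leave open whether 4-fluorophenyl reads the same when combined with the amine-nitrogen group of compound 1, and whether fluoro at another carbon of the ring would do so.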